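Solubility notes on a fused-ring series: aryl versus cyclohexylmethyl

This account rests on a few compounds, and the source may have more. Where it says the series, first, only, none or still open, it means among the compounds named here.

Measured so far:
compound 1, `COc1ccc(F)cc1CNCCCNc1ccnc2cc(-c3ccc(F)cc3)ccc12`, 32000 nM
compound 2, `COc1ccc(F)cc1CNCCCNc1ccnc2cc(CC3CCCCC3)ccc12`, 4200 nM

In a physicochemical assay for solubility, with a stated time of 18 h, at pH 7.4 (a lower number here means a less soluble compound, a higher number a more soluble compound), compound 1 gives 32000 nM, while compound 2 gives 4200 nM. Within the data shown here, compound 2 thus stands at the lower of the two numbers, and the single measured step, a 7.6-fold lower number from compound 1 to compound 2 (0.88 log units; beyond the scatter), separates them.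

Compound 3, `COc1ccc(F)cc1CNCCCNc1ccnc2cc(-c3ccc(C(F)(F)F)cc3)ccc12`, has not yet been measured in this assay. It differs from compound 2 as follows: 4-(trifluoromethyl)phenyl in place of cyclohexylmethyl on an aromatic carbon. This change undoes the aromatic-to-saturated swap of the measured step and returns an aryl group, though with trifluoromethyl rather than fluorine on it. Among the measured compounds shown here, the one step that bears on it, a 7.6-fold lower number from compound 1 to compound 2 (0.88 log units; beyond the scatter), ran downward when the aryl group was lost, so the reverse direction is expected here. Because compound 1 gave 32000 nM, compound 3 is expected to move upward from compound 2 by roughly a 3.6-fold higher number from compound 2 to compound 3 (0.55 log units; beyond the scatter), though perhaps not all the way back. The estimate for compound 3 is 15000 nM, with a range of 5000 nM to 45000 nM.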

Compound 3, solubility: 32000 nM
The estimate for compound 3 lay 2.1-fold (0.33 log units) below the measured number; the range from low to high includes it.
By their numbers in this assay, from the lowest: compound 2; then compounds 1 and 3 (each within the scatter of the next).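

Putting 4-(trifluoromethyl)phenyl in place of cyclohexylmethyl gives a 7.6-fold higher number from compound 2 to compound 3 (0.88 log units; beyond the scatter) in this assay, matching in size the earlier step from the fluorinated aryl compound in the opposite direction. The lower number therefore stands apart from two different aryl groups at this position, not just from 4-fluorophenyl, while trifluoromethyl in place of fluoro gives no change at the digits printed from compound 1 to compound 3 (within the scatter), so the two aryl substituents cannot be told apart in this read-out. No measurement is at hand that explains either step.

Still open, on these data alone, is whether the separation follows the ring type or the methylene link, which a cyclohexyl group attached directly to the aromatic carbon would address. Also open, as far as these compounds go, is how the phenyl ring reads when it carries an amine or a carboxylic acid in place of fluoro or trifluoromethyl.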